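The compounds below may be only part of what the source reports. "The series", "measured", "known", "first", "only" and "open" are said of these compounds alone.

Compound 1 `C[C@H]1C[C@@H](c2ccncc2NC(=O)c2nc(-c3c(F)cccc3F)ncc2N)C[C@@H](O)[C@@]1(O)CF`: 29 mL/min/kg
Compound 2 `C[C@H]1C[C@@H](c2ccncc2NC(=O)c2nc(-c3ncccc3F)ccc2N)C[C@@H](O)[C@@]1(O)CF`: 8 mL/min/kg
Compound 3 `C[C@H]1C[C@@H](c2ccncc2NC(=O)c2nc(-c3ncccc3F)ccc2N)C[C@@H](O)[C@]1(C)O`: 30 mL/min/kg

Three compounds have been run in an ADME assay on microsomes from liver (Homo sapiens) for metabolic stability, read by LC-MS, using NADPH, with a stated time of 30 min, tested at 1 uM; on this read-out lower numbers stand for slow clearance and higher numbers for fast clearance. Compound 2 gives 8 mL/min/kg in this assay. Compound 3 differs from compound 2 by hydrogen in place of fluoro on a saturated chain carbon bound to a saturated ring carbon, and in this assay compound 3 gives 30 mL/min/kg, a step of a 3.8-fold higher number from compound 2 to compound 3 (0.57 log units; beyond the scatter). Compound 1 is built on a different core; the difference between the two cores is not broken down here. In this assay compound 1 gives 29 mL/min/kg, which sits within the scatter of the value of compound 3 and beyond the scatter relative to compound 2.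

Compound 4 `C[C@H]1C[C@@H](c2ccncc2NC(=O)c2nc(-c3c(F)cccc3F)ncc2N)C[C@@H](O)[C@]1(C)O` has not yet been measured. It differs from compound 1 by hydrogen in place of fluoro on a saturated chain carbon bound to a saturated ring carbon, the same change as that made from compound 2 to compound 3. The author expects a step of a 2.8-fold higher number from compound 1 to compound 4 (0.44 log units; beyond the scatter) in this assay from compound 1 to compound 4, kept a little short of the measured one because a 3.8-fold higher number from compound 2 to compound 3 (0.57 log units; beyond the scatter) was seen on a different core and stands as a single pair. Compound 4 is therefore estimated at 80 mL/min/kg, expected to fall between 35 mL/min/kg and 200 mL/min/kg.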

Compound 4, clearance in the Homo sapiens assay: 11 mL/min/kg
Compound 4: middle estimate off by 7.3-fold (0.86 log units), on the high side; the measured number lies below the stated range.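

In the Homo sapiens assay the change from fluoromethyl to methyl on the core of compound 1 gives a 2.6-fold lower number from compound 1 to compound 4 (0.42 log units; beyond the scatter), whereas the same change on the core of compound 2 gave a step in the opposite direction, so its effect on clearance did not carry from one core to the other: the same change on two cores in the Homo sapiens assay, a 3.8-fold higher number (0.57 log units; beyond the scatter) from compound 2 to compound 3 and a 2.6-fold lower number (0.42 log units; beyond the scatter) from compound 1 to compound 4, 9.9-fold (1.00 log units) apart, beyond the scatter of two such steps. On the core of compound 1 the fall in clearance came with a rise in lipophilicity, as a physicochemical assay for lipophilicity, at pH 7.4 (a higher number here means a more lipophilic compound, a lower number a more polar compound), shows: the measured distribution coefficient of compound 1, 1.4, and of compound 4, 2.8, a number 1.40 log units higher (beyond the scatter). In the physicochemical assay compound 1 gives 1.4 and compound 4 gives 2.8. These two pairs show that the direction of this step cannot be assumed on a new core in this series, but they do not show which difference between the cores decides it, and they give no rule for any other core.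

The compounds shown carry only fluoromethyl or methyl on this carbon. On these data alone, how a longer chain such as ethyl, or a hydroxymethyl or difluoromethyl group, would behave there on either core remains open.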